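Dropping the Methoxy Group: Compound 3 to Compound 4

The source may hold more compounds than are shown below. What is called first, only, known or untested is meant among the compounds shown, and "the series" means these compounds.

Measured compounds:
compound 1 `CCn1c(SCC(=O)Nc2ccc(C(C)=O)cc2)nnc1-c1ccc(OC)cc1` with 51%
compound 2 `C=CCn1c(SCC(=O)Nc2ccc(C(C)=O)cc2)nnc1-c1ccc(OC)cc1` with 50%
compound 3 `COc1ccc(-c2nnc(SCC(=O)Nc3ccc(C(C)=O)cc3)n2-c2ccccc2)cc1` with 29%

In a functional assay on the whole organism (strain albino) for inhibition, with Rattus norvegicus as the target, read by paw edema, with stated times of 30 min and 1 h, at a dose of 0.28 mmol/kg by the oral route (on this read-out higher numbers stand for more inhibition at the one dose given (going by the name of the read-out) and lower numbers for less inhibition), compound 3 stands lowest of the three numbers. The nearest is compound 2, with a step of a number 21 percentage points lower from compound 2 to compound 3 (beyond the scatter), and the furthest is compound 1, with a step of a number 22 percentage points lower from compound 1 to compound 3 (beyond the scatter); both steps replace a group on the aromatic nitrogen. The other measured step, a number 1 percentage points lower from compound 1 to compound 2 (within the scatter), stays within the scatter.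

Compound 4 `CC(=O)c1ccc(NC(=O)CSc2nnc(-c3ccccc3)n2-c2ccccc2)cc1` differs from compound 3 by hydrogen in place of methoxy on an aromatic carbon. Going by the values given here, none of the measured steps touches this part of the shared core: all three change the group on the aromatic nitrogen, and the 4-methoxyphenyl stays in place throughout. Among the compounds with values here, there is therefore no measured step that bears on the change, and nothing that points in either direction. Within the data shown here, with the scatter as the only guide, the step of no change at the digits printed from compound 3 to compound 4 (within the scatter) is expected to stay within it. Compound 4 is thus estimated to give 29% in this assay, with a range from 14% to 44%.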

Compound 4, a percentage reported as inhibition, in the whole organism at one dose (the size of the read-out at that dose, not a potency): 41%
Beside the measured number, compound 4's estimate is 12 percentage points below it; the measured number falls inside the stated range.
By their numbers in this assay, from the lowest: compound 3; then compounds 4, 2 and 1 (each within the scatter of the next).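

In this assay, going by these compounds alone, the change from 4-methoxyphenyl to phenyl gives a number 12 percentage points higher from compound 3 to compound 4 (beyond the scatter), the first measured step at this position rather than on the aromatic nitrogen. The methoxy group para to a large group is thus not a silent part of the shared core: with phenyl on the aromatic nitrogen, hydrogen in its place moves the read-out beyond the scatter. No measurement shown here gives a reason for this step.

Going by these compounds, whether hydrogen in place of methoxy would move the read-out the same way with ethyl or allyl on the aromatic nitrogen remains open, as compound 1 and compound 2 both keep the 4-methoxyphenyl. Also open, on these data alone, is what a hydroxy group, a chlorine atom or an amine would give at this place.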